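A few compounds are considered here, and "the series" means these few. Any claim that something is new, unique, unknown or untested is made for them only; others in the source may bear on it.

Among the measured compounds shown here, in a functional assay on NCI-H460 cells (Homo sapiens) for inhibition, read by MTT assay, with a stated time of 24 h, tested at 100 ug/mL (on this read-out higher numbers stand for more inhibition of growth at the one concentration tested and lower numbers for less inhibition of growth), compound 1 (`O=C(O)CCCCC(CCSC(=O)c1ccccc1)SC(=O)c1ccccc1`) gives 72.8% and stands highest of the two numbers so far. Compound 2 (`CC(=O)SCCC(CCCCC(=O)Nc1cccc(Cl)c1)SC(C)=O`) gives 42.8% in the same read-out. The gap between these two numbers lies beyond the scatter. Compound 3 (`O=C(CCCCC(CCSC(=O)c1ccccc1)SC(=O)c1ccccc1)Nc1ccc(Cl)cc1`) carries (4-chlorophenyl)amino in place of hydroxy on a carbonyl carbon of compound 1 ((4-chlorophenyl)amino in place of hydroxy on a carbonyl carbon) and so has no carboxy. For the measured compounds named here, no measured step isolates this change. Going by the values given here, compound 2 also has no carboxy and reads 42.8% as the only guide. A fall beyond the scatter is expected in this assay and is estimated as (a number 17.8 percentage points lower from compound 1 to compound 3 (beyond the scatter)). Compound 3 is estimated at 55% (range 33% to 78%).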

Compound 3, percent growth inhibition at one concentration: "not active" (no number reported)
No number was reported for compound 3; the estimate stays without a comparison.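

Among the compounds shown here, compound 3 is reported as not active, without a number, so no step from compound 1 to compound 3 can be read. No measured evidence bears on this result. The compounds shown leave open what (4-chlorophenyl)amino in place of hydroxy does by itself.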